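Working notes: nitro in place of fluoro, compound 4

A few compounds are considered here, and "the series" means these few. Any claim that something is new, unique, unknown or untested is made for them only; others in the source may bear on it.

In a functional assay on KB cells (Homo sapiens) for inhibition, read by MTT assay, with a stated time of 24 h, tested at 10 ug/mL (on this read-out higher numbers stand for more inhibition of growth at the one concentration tested and lower numbers for less inhibition of growth), compound 1 `O=C(CCCCC(S)CCS)Nc1ccc(F)cc1` gives 13.3%. Compound 3 `Cc1cccc(NC(=O)CCCCC(S)CCS)c1` gives 7.23%, which lies within the scatter of compound 1. Compound 2 `O=C(CCCCC(S)CCS)Nc1cccc(C(F)(F)F)c1` gives 1.97%, which lies lower than compound 1 by more than the scatter.

The next compound to be tested is compound 4 `O=C(CCCCC(S)CCS)Nc1ccc([N+](=O)[O-])cc1`, which differs from compound 1 as follows: nitro in place of fluoro on an aromatic carbon. In words, this is nitro in place of fluoro on an aromatic carbon, para to a large group.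

Among the compounds with values here, only one measured step bears on this, and only loosely: methyl in place of trifluoromethyl on an aromatic carbon, a number 5.3 percentage points higher from compound 2 to compound 3 (within the scatter). Within the data shown here, that step exchanges a different pair of groups, and no measured compound carries nitro. The data therefore give no ground to expect a step beyond the scatter.

The expected change is a number 4.3 percentage points lower from compound 1 to compound 4 (within the scatter), a modest pull toward the other two measured numbers. For compound 4 the estimated value is 9%, with an expected range from 1% to 21%.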

Compound 4, percent growth inhibition at one concentration: 13.7%
For compound 4 the middle estimate is 4.7 percentage points below the measured one; measured number inside the range.
By their numbers in this assay, from the lowest: compounds 2, 3, 1 and 4 (each within the scatter of the next, the first and the last beyond it).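

In this assay, the exchange on an aromatic carbon, para to a large group, gives a number 0.4 percentage points higher from compound 1 to compound 4 (within the scatter). Within the data shown here, this is the first direct reading at this position, since the earlier step exchanged a different pair of groups on differently substituted compounds. Here 3 heavy atoms and 2 hydrogen-bond acceptors enter where 1 heavy atom and 0 hydrogen-bond acceptors leave, and between compound 1 and compound 4 this exchange does not separate the numbers. No measurement in hand accounts for this outcome.

From the compounds shown here alone, whether an amine or a carboxylic acid in the same place would give a step beyond the scatter remains open. So does the effect of a longer chain in place of the one shared by these compounds.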